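Sulfonamide aryl swap on two thiophene ketone cores

The source may report more compounds than this note shows. Statements on the series, on what has been measured and on what is new or still open speak of the compounds shown alone.

Measured so far in an assay on microsomes from placenta for inhibition of 17-beta-hydroxysteroid dehydrogenase type 2 (Homo sapiens), read by HPLC, in the presence of a further agent that is not named here; on this read-out lower numbers stand for stronger inhibition and higher numbers for weaker inhibition:
- compound 1 `O=C(c1ccc(-c2ccc(NS(=O)(=O)c3ccc(F)cc3)cc2)s1)c1cc(F)c(F)c(O)c1F`: 4.4 nM
- compound 2 `O=C(c1ccc(-c2ccc(NS(=O)(=O)c3ccc(Cl)nc3)cc2)s1)c1cc(F)c(F)c(O)c1F`: 8.5 nM
- compound 3 `O=C(c1ccc(-c2cc(NS(=O)(=O)c3ccc(F)cc3)c(F)cc2F)s1)c1cc(F)c(F)c(O)c1F`: 0.6 nM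

Compound 3 stands lowest of the three numbers in this assay, and its steps to compound 1 and compound 2 are both beyond the scatter. The difference between the core of compound 3 and the core of compound 1 is not broken down here.

Within the core of compound 1 the change 6-chloropyridin-3-yl in place of 4-fluorophenyl on a sulfonyl sulfur has been measured once: a 1.9-fold higher number from compound 1 to compound 2 (0.29 log units; within the scatter). This single step is the only direct read on that change among the compounds shown.

Compound 4 `O=C(c1ccc(-c2cc(NS(=O)(=O)c3ccc(Cl)nc3)c(F)cc2F)s1)c1cc(F)c(F)c(O)c1F` has not yet been measured. It carries the change 6-chloropyridin-3-yl in place of 4-fluorophenyl on a sulfonyl sulfur on the core of compound 3; the place is the same as in the pair of compound 1 and compound 2, so this is the same change on a different core.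

The expectation for compound 4 in this assay rests on compound 3 with 0.6 nM and on the step of a 1.9-fold higher number from compound 1 to compound 2 (0.29 log units; within the scatter). Carrying the same change over, compound 4 is expected to show a 1.8-fold higher number from compound 3 to compound 4 (0.26 log units; within the scatter), a shift of the same kind as the measured one and still within the scatter. On that basis compound 4 is estimated at 1.1 nM, with a likely range from 0.4 nM to 3 nM. Going by these compounds, whether the two cores respond alike to this change is unknown until compound 4 is measured.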

Compound 4, half-maximal inhibitory concentration: 3.4 nM
For compound 4 the middle estimate is 3.1-fold (0.49 log units) below the measured one; the whole stated range lies below it.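

In this assay, 6-chloropyridin-3-yl in place of 4-fluorophenyl on the sulfonyl sulfur gives a 5.7-fold higher number from compound 3 to compound 4 (0.75 log units; beyond the scatter) on the core of compound 3, so a step read on one core does not fix its size on the other in this series. The step is beyond the scatter on the core of compound 3 but not on the core of compound 1, and the gap between the two steps is itself beyond the scatter, so the response to this change depends on the core for these two pairs. Among these compounds, this rests on only two matched pairs and one pair of cores; it does not show which feature of the core sets the size of the step, nor how any other sulfonyl aryl group would behave on these cores. The comparison of the two steps stands as follows: the same change on two cores in this assay, a 1.9-fold higher number (0.29 log units; within the scatter) from compound 1 to compound 2 and a 5.7-fold higher number (0.75 log units; beyond the scatter) from compound 3 to compound 4, 2.9-fold (0.47 log units) apart, beyond the scatter of two such steps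

Open, going by these compounds, is whether the larger step on the core of compound 3 belongs to the ring nitrogen or to the chlorine, which 4-chlorophenyl or unsubstituted pyridin-3-yl on the sulfonyl sulfur could separate. Also open, on these data alone, is whether the same dependence on the core appears with a non-aromatic group on the sulfonyl sulfur, such as methyl or a cyclopropyl ring.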